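The source may report more compounds than this note shows. Statements on the series, on what has been measured and on what is new or still open speak of the compounds shown alone.

Compound 1 `O=C(NCc1ccc(S(=O)(=O)C2CCCOC2)cc1)N1Cc2ccncc2C1`: 32 nM
Compound 2 `CCC(=O)N1CCC(S(=O)(=O)c2ccc(CNC(=O)N3Cc4ccncc4C3)cc2)CC1`: 54 nM
Compound 3 `O=C(NCc1ccc(S(=O)(=O)C2CCN(C3COC3)CC2)cc1)N1Cc2ccncc2C1`: 7.4 nM

In a functional assay on A2780 cells (Homo sapiens) for cytotoxicity, read by sulforhodamine B assay, with a stated time of 72 h (on this read-out higher numbers stand for weaker inhibition and lower numbers for stronger inhibition), compound 3 gives 7.4 nM, the lowest of these three numbers. Compound 4 `O=C(NCc1ccc(S(=O)(=O)N2CCC(O)CC2)cc1)N1Cc2ccncc2C1` has not been measured. In it, 4-hydroxypiperidin-1-yl takes the place of 1-(oxetan-3-yl)piperidin-4-yl on a sulfonyl sulfur: 4-hydroxypiperidin-1-yl in place of 1-(oxetan-3-yl)piperidin-4-yl on a sulfonyl sulfur.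

The closest evidence comes from two steps that also change the group on the sulfonyl sulfur, a 4.3-fold lower number from compound 1 to compound 3 (0.64 log units; beyond the scatter) and a 7.3-fold lower number from compound 2 to compound 3 (0.86 log units; beyond the scatter). A third step between the other two groups, a 1.7-fold higher number from compound 1 to compound 2 (0.23 log units; within the scatter), is small. For the measured compounds named here, no measured compound carries 4-hydroxypiperidin-1-yl, so the uncertainty is wide.

A modest rise in the number is expected in this assay, an expected step of a 4.1-fold higher number from compound 3 to compound 4 (0.61 log units; beyond the scatter). The estimated value for compound 4 is 30 nM, with an expected range of 10 nM to 90 nM.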

Compound 4, half-maximal inhibitory concentration: 98 nM
The estimate for compound 4 lay 3.3-fold (0.51 log units) below the measured number; the measured number lies above the stated range.
By their numbers in this assay, from the lowest: compound 3; then compounds 1, 2 and 4 (each within the scatter of the next, the first and the last beyond it).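

In this assay the 4-hydroxypiperidin-1-yl group on the sulfonyl sulfur gives the largest step seen so far at this position, with a 13-fold higher number from compound 3 to compound 4 (1.12 log units; beyond the scatter) and so loses the gain that 1-(oxetan-3-yl)piperidin-4-yl brought. The other two comparisons are milder: there is a 3.1-fold higher number from compound 1 to compound 4 (0.49 log units; beyond the scatter) and a 1.8-fold higher number from compound 2 to compound 4 (0.26 log units; within the scatter). No measurement shown here accounts for these steps. From the compounds shown here alone, it remains open whether the hydroxy group or the attachment through the ring nitrogen carries the step. An unsubstituted piperidin-1-yl or a 4-aminopiperidin-1-yl group at this place would help separate the two.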